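Same Ring Swap, Second Time: Solubility Outlook for Compound 4

A few compounds are considered here, and "the series" means these few. Any claim that something is new, unique, unknown or untested is made for them only; others in the source may bear on it.

Three measured compounds share one core and differ at two places. Compound 2 `COc1ccc(F)cc1CNCCCNc1ccnc2cc(CC3CCCCC3)ccc12` carries cyclohexyl on a saturated chain carbon bound to an aromatic carbon and 5-fluoro-2-methoxyphenyl on a saturated chain carbon bound to an amine nitrogen. In a physicochemical assay for solubility, with a stated time of 18 h, at pH 7.4 (on this read-out higher numbers stand for higher solubility and lower numbers for lower solubility), compound 2 gives 4200 nM. Compound 1 `COc1ccc(F)cc1CNCCCNc1ccnc2cc(Cc3ccc(F)cc3Cl)ccc12` differs from compound 2 by 2-chloro-4-fluorophenyl in place of cyclohexyl on a saturated chain carbon bound to an aromatic carbon. In this assay compound 1 gives 4200 nM, and no change at the digits printed from compound 2 to compound 1 (within the scatter). Compound 3 `COc1cccc(CNCCCNc2ccnc3cc(CC4CCCCC4)ccc23)c1O` differs from compound 2 at the other place, by 2-hydroxy-3-methoxyphenyl in place of 5-fluoro-2-methoxyphenyl on a saturated chain carbon bound to an amine nitrogen. In this assay compound 3 gives 4200 nM, and no change at the digits printed from compound 2 to compound 3 (within the scatter). Compound 4 `COc1cccc(CNCCCNc2ccnc3cc(Cc4ccc(F)cc4Cl)ccc23)c1O` has not yet been measured. It differs from compound 3 by 2-chloro-4-fluorophenyl in place of cyclohexyl on a saturated chain carbon bound to an aromatic carbon, which is the same change, at the same place, as that from compound 2 to compound 1. Because no change at the digits printed from compound 2 to compound 1 (within the scatter), the expected step in this assay is no change at the digits printed from compound 3 to compound 4 (within the scatter), with nothing among these compounds pointing another way. Compound 4 is therefore estimated at 4200 nM, expected to fall between 2100 nM and 8400 nM.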

Compound 4, solubility: 4200 nM
Beside the measured number, compound 4's estimate shows no gap at the digits printed; measured number inside the range.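

In this assay, putting 2-chloro-4-fluorophenyl in place of cyclohexyl gives no change at the digits printed from compound 3 to compound 4 (within the scatter), which reads the same as no change at the digits printed from compound 2 to compound 1 (within the scatter), and the remaining new step agrees, with no change at the digits printed from compound 1 to compound 4 (within the scatter). The change therefore carries over in these two pairs, with either 5-fluoro-2-methoxyphenyl or 2-hydroxy-3-methoxyphenyl on a saturated chain carbon bound to an amine nitrogen, but this is one flat step repeated once, and it does not show that the change would stay flat with other groups at that place or how a step of real size would carry over. Nothing shown accounts for the four compounds standing level.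

As far as these compounds go, whether an amine or a carboxylic acid in place of 2-chloro-4-fluorophenyl on a saturated chain carbon bound to an aromatic carbon would shift the read-out stays open. The compounds shown also leave open whether a pyridine in place of 2-hydroxy-3-methoxyphenyl would keep the value level.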